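This account rests on a few compounds, and the source may have more. Where it says the series, first, only, none or still open, it means among the compounds named here.

Measured compounds:
compound 1, `COc1ccc(-c2nn(-c3ccccc3)cc2C(=O)NOCc2ccc(Cl)cc2Cl)cc1`, gives 3830 nM
compound 2, `O=C(NOCc1ccccc1)c1cn(-c2ccccc2)nc1-c1ccc(Cl)cc1`, gives 13000 nM
compound 3, `O=C(NOCc1ccccc1F)c1cn(-c2ccccc2)nc1-c1ccc(Cl)cc1`, gives 12100 nM

All three were tested in a functional assay on A549 cells (Homo sapiens) for antiproliferative activity, read by MTT assay, with a stated time of 48 h, in the presence of a further agent that is not named here; on this read-out higher numbers stand for weaker inhibition of growth and lower numbers for stronger inhibition of growth. Among these numbers compound 3 stands second highest; its nearest neighbour is compound 2, and the one measured step, a 1.1-fold lower number from compound 2 to compound 3 (0.03 log units; within the scatter), lies within the scatter, so the two compounds cannot be placed in any order. For the measured compounds named here, compound 1 stands furthest away, with a lower number that lies beyond the scatter, but compound 1 differs from compound 3 in two places at once, so no single step connects them.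

Compound 4, `O=C(NOCc1ccc(Cl)cc1Cl)c1cn(-c2ccccc2)nc1-c1ccc(Cl)cc1`, has not yet been measured. It differs from compound 3 in one place only: 2,4-dichlorophenyl in place of 2-fluorophenyl on a saturated chain carbon bound to an oxygen. Going by the values given here, no measured step addresses this exact change. Among the compounds with values here, the only hint is that compound 1, which carries the same 2,4-dichlorobenzyl group, gives a lower number than compound 3, yet compound 1 also differs elsewhere, so that comparison carries little weight. Compound 4 is therefore expected to give a somewhat lower number than compound 3, with the step of a 1.9-fold lower number from compound 3 to compound 4 (0.27 log units; within the scatter) carrying wide uncertainty. The estimate for compound 4 in this assay is 6500 nM, with a range from 2000 nM to 20000 nM.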

Compound 4, concentration for 50% growth inhibition: 13100 nM
Compound 4: the middle estimate sits 2.0-fold (0.30 log units) below what was measured; low and high end bracket the measured number.
By their numbers in this assay, from the lowest: compound 1; then compounds 3, 2 and 4 (each within the scatter of the next).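

In this assay the step of a 1.1-fold higher number from compound 3 to compound 4 (0.03 log units; within the scatter) and the step of a 1.0-fold higher number from compound 2 to compound 4 (0.00 log units; within the scatter) both lie within the scatter, so phenyl, 2-fluorophenyl and 2,4-dichlorophenyl cannot be told apart on this saturated chain carbon bound to an oxygen when the rest of the molecule is the same. The one clear difference lies in another place: with 2,4-dichlorobenzyl held constant, chloro in place of methoxy on an aromatic carbon gives a 3.4-fold higher number from compound 1 to compound 4 (0.53 log units; beyond the scatter) and this modest step lies beyond the scatter, so the lower number of compound 1 goes with its methoxy group and not with the 2,4-dichlorobenzyl group it carries. No measurement at hand gives a reason for either finding.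

For the compounds shown here, compound 1 is the only compound here with methoxy, so it remains open whether methoxy would go with a lower number alongside plain benzyl or 2-fluorobenzyl as well. As far as these compounds go, it also remains open whether this position tolerates any change at all, since an amine or a carboxylic acid on the benzyl ring, or a longer chain in place of benzyl, might behave quite differently from the halogen-bearing rings compared here.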